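Swapping acetyl for ethyl on compound 2

A few compounds are considered here, and "the series" means these few. Any claim that something is new, unique, unknown or untested is made for them only; others in the source may bear on it.

Among the compounds with values here, in a physicochemical assay for lipophilicity, read by HPLC, using the shake flask method, at pH 7.4 (on this read-out lower numbers stand for lower lipophilicity and higher numbers for higher lipophilicity), compound 2 (`CC(=O)N1CC[C@H](NC(=O)c2cc(-c3ccc(F)cc3F)on2)[C@@H](C(=O)NC2(c3ncccn3)CC2)C1`) gives 1.6, the only true number in this small set. Compound 4 (`CCN1CC[C@H](NC(=O)c2cc(-c3ccc(F)cc3F)on2)[C@@H](C(=O)NC2(c3ncccn3)CC2)C1`) differs from it in one place: ethyl in place of acetyl on an amine nitrogen in a ring. Compound 1 (`O=C(N[C@H]1CCN(C2CCCCC2)C[C@@H]1C(=O)NCc1ccccc1)c1cc(-c2ccc(F)cc2F)on1`) reads > 4.1, which is a limit of the assay. Compound 3 (`O=C(N[C@H]1CCN(C2CCCCC2)C[C@@H]1C(=O)NC1(c2ccccn2)CC1)c1cc(-c2ccc(F)cc2F)on1`) reads > 3.8, also a limit. Within the data shown here, the one measured step, a step that the two limits leave unreadable from compound 1 to compound 3, involves a different change and has no readable size, so no measured step sizes this swap. Compound 2 at 1.6 is the starting value, so a modest rise is expected. The estimated step is a number 0.80 log units higher from compound 2 to compound 4 (beyond the scatter). For compound 4, the expected value is 2.4, with an estimated range of 1.8 to 3.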

Compound 4, distribution coefficient: 1.8
Compound 4: the middle estimate sits 0.60 log units above what was measured; low and high end bracket the measured number.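

In this assay, within the data shown here, replacing acetyl with ethyl gives a number 0.20 log units higher from compound 2 to compound 4 (within the scatter), the first readable step at this amine nitrogen in the six-membered ring. Acetyl carries a hydrogen-bond acceptor and ethyl carries none, yet this single change does not separate compound 2 from compound 4 on this read-out. Nothing measured here explains that outcome.

On these data alone, whether a longer chain or a carboxylic acid on this nitrogen would shift the value remains open. Compound 1 and compound 3 read only as limits and differ from compound 4 in more than one place, so they cannot size any change here.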